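A few compounds are considered here, and "the series" means these few. Any claim that something is new, unique, unknown or untested is made for them only; others in the source may bear on it.

Compound 1, `CC(=O)Nc1ccc(-c2nc3cc(C(F)(F)F)ccc3n2C)cc1`, in an ADME assay on BHK cells (Mesocricetus auratus) for cytotoxicity, read by MTT assay, with a stated time of 96 h (on this read-out higher numbers stand for lower toxicity in this test and lower numbers for higher toxicity in this test), gives only a limit, > 100000 nM.
Compound 2, `CC(=O)Nc1ccc(-c2nc3ccccc3[nH]2)cc1`, in this assay also gives only a limit, > 100000 nM.
Compound 3, `CCC(=O)Nc1ccc(-c2nc3cc(C(F)(F)F)ccc3n2C)cc1`, in this assay likewise gives only a limit, > 100000 nM.

Compound 3 differs from compound 1 by methyl in place of hydrogen on a saturated chain carbon bound to a carbonyl carbon. The step that the two limits leave unreadable from compound 1 to compound 3 is not readable; both of its ends are limits. Compound 2 carries a different core from compound 1, and the difference between the two cores is not broken down here; compound 2 stands at a limit as well. Compound 4, `CCC(=O)Nc1ccc(-c2nc3ccccc3[nH]2)cc1`, is not yet measured. It differs from compound 2 by methyl in place of hydrogen on a saturated chain carbon bound to a carbonyl carbon, the same change as that from compound 1 to compound 3, at the same place. Because (the limit of > 100000 nM in this assay, at which 3 of the 3 values shown sit), there is no sign that this change brings toxicity in this assay into the measurable range. The expected step that the limit leaves unreadable from compound 2 to compound 4 is accordingly small. Compound 4 is estimated at 200000 nM, with a plausible span from 70000 nM to 600000 nM, and is most likely to be reported once more as a limit.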

Compound 4, half-maximal cytotoxic concentration: >= 100000 nM
Compound 4: no number, only a limit (the forecaster's own chance of this, stated with the estimate: 85%); the middle value does not contradict the limit.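

In this assay compound 4 gives >= 100000 nM, a limit and not a number. Going by these compounds alone, compound 2 gives > 100000 nM, likewise a limit, so no step from compound 2 to compound 4 can be read. The compounds shown leave open whether any of them reaches a measurable half-maximal cytotoxic concentration in this assay, and so what any change among them does.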